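From compound 3 to compound 4: one group exchanged

This account rests on a few compounds, and the source may have more. Where it says the series, first, only, none or still open, it means among the compounds named here.

Compound 1 `COc1cc2c(Nc3ccc(C#N)cc3)ncnc2cc1OCCCN1CCC(O)CC1`: > 100000 nM (a limit)
Compound 2 `COc1cc2c(Nc3ccc(C#N)cc3)ncnc2cc1OCCCN1CCc2ccccc2C1`: > 100000 nM (a limit)
Compound 3 `COc1cc2c(Nc3ccc(C#N)cc3)ncnc2cc1OCCCN1CCC(N2CCCCC2)CC1`: 9810 nM

All three compounds were tested in a functional assay on SH-SY5Y cells (Homo sapiens) for antiproliferative activity, read by MTT assay, with a stated time of 72 h; on this read-out higher numbers stand for weaker inhibition and lower numbers for stronger inhibition. Among the compounds with values here, compound 3 is the only one that gives a number rather than a limit, and the series is bounded by the limit of > 100000 nM in this assay, at which 2 of the 3 values shown sit.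

Compound 4 `COc1cc2c(Nc3ccc(C#N)cc3)ncnc2cc1OCCCN1CCN(C)CC1` differs from compound 3 in one place: 4-methylpiperazin-1-yl in place of 4-(piperidin-1-yl)piperidin-1-yl on a saturated chain carbon, three bonds along the chain from an oxygen on an aromatic ring. It carries 4-methylpiperazin-1-yl in place of 4-(piperidin-1-yl)piperidin-1-yl on a saturated chain carbon, three bonds along the chain from an oxygen on an aromatic ring.

Within the data shown here, no measured step makes this exact exchange. Among the measured compounds shown here, two measured steps bear on it, as both lead into compound 3: an at least 10-fold lower number from compound 1 to compound 3 (1.00 log units; beyond the scatter), and an at least 10-fold lower number from compound 2 to compound 3 (1.00 log units; beyond the scatter). The remaining step, a step that the two limits leave unreadable from compound 1 to compound 2, gives no size. On the strength of an at least 10-fold lower number from compound 2 to compound 3 (1.00 log units; beyond the scatter), losing the group of compound 3 is expected to raise the number in this assay, towards weaker inhibition, and a result at the limit would be no surprise. The expected change is a 4.1-fold higher number from compound 3 to compound 4 (0.61 log units; beyond the scatter). The estimated value for compound 4 is 40000 nM, with an expected range from 12000 nM to 100000 nM.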

Compound 4, half-maximal inhibitory concentration: 13000 nM
Compound 4: the middle estimate sits 3.1-fold (0.49 log units) above what was measured, within the range that was stated.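

In this assay, the exchange on a saturated chain carbon, three bonds along the chain from an oxygen on an aromatic ring, gives a 1.3-fold higher number from compound 3 to compound 4 (0.12 log units; within the scatter). Within the data shown here, the 4-(piperidin-1-yl)piperidin-1-yl group, with its 12 heavy atoms, is therefore not the only group here that gives a number rather than a limit, and 4-methylpiperazin-1-yl, with 7 heavy atoms, does so too, within the scatter of compound 3. The other two steps, an at least 7.6-fold lower number from compound 2 to compound 4 (0.88 log units; beyond the scatter) and an at least 7.6-fold lower number from compound 1 to compound 4 (0.88 log units; beyond the scatter), set compound 4 apart from the two weaker compounds, but their sizes are only bounds, not exact steps: the limit of > 100000 nM in this assay, at which 2 of the 4 values shown sit.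

The compounds shown leave open whether a morpholin-4-yl or a plain piperidin-1-yl group at the end of this chain would also give a number in this assay. They also leave open how a shorter or longer chain, or an amide or a carboxylic acid in place of the nitrile on the shared core, would behave with 4-methylpiperazin-1-yl in place.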